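Methoxy step carried from one core to the other

The source may hold more compounds than are shown below. What is called first, only, known or untested is meant among the compounds shown, and "the series" means these compounds.

Compound 1 `C=C(C)[C@@H]1CC=C(Cn2cc(COc3ccc(C4NC(=O)NC(C)=C4C(C)=O)cc3)nn2)CC1` and compound 2 `C=C(C)[C@@H]1CC=C(Cn2cc(COc3ccc(C4NC(=O)NC(C)=C4C(C)=O)cc3OC)nn2)CC1` share one core; compound 3 `C=C(C)[C@@H]1CC=C(Cn2cc(COc3ccc(C4NC(=O)NC5=C4C(=O)CC(C)(C)C5)cc3)nn2)CC1` and the unmeasured compound 4 `C=C(C)[C@@H]1CC=C(Cn2cc(COc3ccc(C4NC(=O)NC5=C4C(=O)CC(C)(C)C5)cc3OC)nn2)CC1` share another. The difference between the two cores is not broken down here. In a functional assay on UACC-62 cells (Homo sapiens) for inhibition, read by sulforhodamine B assay, with a stated time of 48 h (on this read-out higher numbers stand for weaker inhibition of growth and lower numbers for stronger inhibition of growth), compound 1 gives 20500 nM, compound 2 gives 3830 nM and compound 3 gives 29900 nM. Compound 3 stands nearest to compound 1, within the scatter, and furthest from compound 2.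

The change from compound 1 to compound 2 is methoxy in place of hydrogen on an aromatic carbon and made a 5.4-fold lower number from compound 1 to compound 2 (0.73 log units; beyond the scatter). The change from compound 3 to compound 4 is methoxy in place of hydrogen on an aromatic carbon, the same change on the other core; among the compounds shown it occurs twice. Whether the step transfers across cores rests on a single pair, so the expectation carries wide bounds. A step of about the same size is expected, a 4.6-fold lower number from compound 3 to compound 4 (0.66 log units; beyond the scatter), because compound 1 to compound 2 showed a 5.4-fold lower number from compound 1 to compound 2 (0.73 log units; beyond the scatter). On that basis compound 4 is estimated at 6500 nM in this assay, expected to fall between 2500 nM and 17000 nM.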

Compound 4, concentration for total growth inhibition: 86200 nM
Compound 4: the middle estimate sits 13-fold (1.12 log units) below what was measured; measured number above the stated range.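

In this assay, methoxy in place of hydrogen on an aromatic carbon gave a 2.9-fold higher number from compound 3 to compound 4 (0.46 log units; beyond the scatter), so the direction of the step seen on the core of compound 1 did not carry over to the core of compound 3. The two steps differ in direction and lie apart: the same change on two cores in this assay, a 5.4-fold lower number (0.73 log units; beyond the scatter) from compound 1 to compound 2 and a 2.9-fold higher number (0.46 log units; beyond the scatter) from compound 3 to compound 4, 15-fold (1.19 log units) apart, beyond the scatter of two such steps

For these four compounds, the effect of this change therefore cannot be carried from one core to the other, but with a single pair on each core this does not show why the steps part, nor how general the reversal is across the series.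

Open, going by these compounds, is whether a hydroxyl or an ethoxy group at the same place would follow the step on the core of compound 1 or the step on the core of compound 3. Also open, on these data alone, is which part of the difference between the two cores goes with the opposite steps.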